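The compounds below may be only part of what the source reports. "The series", "measured", "known", "first", "only" and "open" are said of these compounds alone.

In an ADME assay on GES1 cells (Homo sapiens) for inhibition, read by MTT assay, with a stated time of 72 h (a lower number here means a stronger inhibitor, a higher number a weaker inhibitor), compound 1 `Cc1cc(Nc2ccn(Cc3cccc4ccccc34)n2)n2nc(SCc3ccc(Br)cc3)nc2n1` gives 30000 nM. Compound 2 `Cc1cc(Nc2cc(-c3ccccc3)[nH]n2)n2nc(SCc3ccc(Br)cc3)nc2n1`, which carries a different substituent on the shared core, gives 39300 nM. Going by the values given here, these two numbers lie within the usual scatter of each other, so compound 1 stands level with the only other measured compound.

Compound 3 `Cc1ccc(Cn2ccc(Nc3cc(C)nc4nc(SCc5ccc(Br)cc5)nn34)n2)cc1` has not yet been measured in this assay. It departs from compound 1 in one place: 4-methylphenyl in place of naphthalen-1-yl on a saturated chain carbon bound to an aromatic nitrogen. Here 4-methylphenyl stands in place of naphthalen-1-yl on a saturated chain carbon bound to an aromatic nitrogen, which turns the (naphthalen-1-yl)methyl group into 4-methylbenzyl.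

Among the compounds with values here, no measured pair of compounds shows what a change of this kind does, so the data favour no direction. The expectation rests only on the closest parent, compound 1 at 30000 nM, and no shift beyond the scatter is expected. The estimated step of a 1.1-fold higher number from compound 1 to compound 3 (0.04 log units; within the scatter) is therefore small. For compound 3 the expected value is 33000 nM, with an estimated range from 15000 nM to 70000 nM.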

Compound 3, half-maximal inhibitory concentration: > 50000 nM
Compound 3 gave a limit, no number; the forecaster's own chance of this, stated with the estimate: 15%; middle value at least 1.5-fold (0.18 log units) from the limit.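

In this assay compound 3 gives > 50000 nM, which is a limit of the assay and not a number. Going by these compounds alone, putting 4-methylphenyl in place of naphthalen-1-yl on a saturated chain carbon bound to an aromatic nitrogen, so that one six-membered aromatic ring stands where there were two, gives the first step that can be read at this position: an at least 1.6-fold higher number from compound 1 to compound 3 (0.22 log units; that floor lies within the scatter). The step therefore points only one way, with no sign of a lower number, but its size stays open, and it cannot be said to clear the scatter, because the value of compound 3 is only a limit: the limit of > 50000 nM in this assay, at which 1 of the 3 values shown sits.

The compounds shown leave open whether the loss of the second ring or the arrival of the methyl group governs this step, since both come with the same change, and a plain phenyl group at this place would separate the two. They also leave open how naphthalen-2-yl, or a 4-methylphenyl replaced by a phenyl ring carrying a carboxylic acid or an amine, would read in this assay.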